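Fixing One Stereocentre in Compound 1

A few compounds are considered here, and "the series" means these few. Any claim that something is new, unique, unknown or untested is made for them only; others in the source may bear on it.

Among the measured compounds shown here, compound 1 `CC1(CO)OCC(n2ccc(N)nc2=O)O1` is the only compound here with a number: in a functional assay on L1210 cells (Mus musculus) for inhibition (a lower number here means a stronger inhibitor, a higher number a weaker inhibitor), compound 1 gives 50000 nM. Compound 2 `C[C@]1(CO)OCC(n2cc(F)c(N)nc2=O)O1` is reported in this assay only as a limit, > 100000 nM; this is the limit of > 100000 nM in this assay, at which 1 of the 2 values shown sits. Compound 3 `CC1(CO)OC[C@@H](n2ccc(N)nc2=O)O1` differs from compound 1 as follows: the two compounds have the same atoms and bonds; at least one stereo element is drawn with a configuration in one of them and without one in the other: 1 of 2 stereo elements differ; a stereocentre at a saturated ring carbon is drawn without a configuration in compound 1 and S in compound 3. For the measured compounds named here, no measured pair shows how drawing a configuration at that centre changes the read-out, so compound 3 is expected to stay within the scatter of compound 1, with the step of a 1.3-fold lower number from compound 1 to compound 3 (0.10 log units; within the scatter) possible in either direction. Compound 3 is accordingly expected to give 40000 nM, between 15000 nM and 120000 nM.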

Compound 3, half-maximal inhibitory concentration: > 100000 nM
Compound 3: a limit, no number; the forecaster's own chance of this, stated with the estimate: 30%; middle value at least 2.5-fold (0.39 log units) from the limit.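

With the saturated ring carbon drawn as S, compound 3 gives only a limit in this assay, > 100000 nM. The comparison is an at least 2.0-fold higher number from compound 1 to compound 3 (0.30 log units; that floor lies within the scatter), so this first reading at the stereocentre sets a floor, gives no size for the change, and does not establish a loss of inhibition. The result also adds to the values held at one ceiling: the limit of > 100000 nM in this assay, at which 2 of the 3 values shown sit.

Going by these compounds, what the opposite configuration at this centre would give stays open. So does whether an amine or a carboxylic acid on the shared core would return a measurable number.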